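An Amino Group Added to Compound 1

The compounds below may be only part of what the source reports. "The series", "measured", "known", "first", "only" and "open" are said of these compounds alone.

Compound 1 `COc1cc(C(=O)c2cn(-c3ccccc3)cc2-c2ccccc2Cl)cc(OC)c1OC` gives 76 nM in a functional assay on MCF7 cells (Homo sapiens) for cytotoxicity, read by MTT assay, with a stated time of 96 h (on this read-out higher numbers stand for weaker inhibition and lower numbers for stronger inhibition), and stands level with compound 2 `COc1cc(C(=O)c2cn(-c3ccccc3)cc2-c2cccc([N+](=O)[O-])c2)cc(OC)c1OC` at 50 nM on these numbers, since a 1.5-fold lower number from compound 1 to compound 2 (0.18 log units; within the scatter) is all that separates them. Compound 3 `COc1cc(C(=O)c2cn(-c3ccccc3)cc2/C=C/c2ccccc2)cc(OC)c1OC` gives 2200 nM and lies far from both, with a 29-fold higher number from compound 1 to compound 3 (1.46 log units; beyond the scatter) and a 44-fold higher number from compound 2 to compound 3 (1.64 log units; beyond the scatter) as the two large steps.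

Compound 4 `COc1cc(C(=O)c2cn(-c3ccc(N)cc3)cc2-c2ccccc2Cl)cc(OC)c1OC` keeps the rest of compound 1 and differs in one place, amino in place of hydrogen on an aromatic carbon para to a large group. The same change reads as phenyl to 4-aminophenyl.

All three measured steps exchange a different group, among 2-chlorophenyl, 3-nitrophenyl and 2-phenylethenyl, so none of them tests this phenyl. They show that a single exchange elsewhere in these compounds can move the number a long way, as with compound 3, but they give no direction for an added amino group. Among the measured compounds shown here, with no direct precedent, no step beyond the scatter is expected, and the estimate amounts to a 1.9-fold lower number from compound 1 to compound 4 (0.28 log units; within the scatter) in this assay as the expected outcome. For compound 4 the estimated value is 40 nM with an expected range from 10 nM to 150 nM (kept wide for lack of a direct precedent).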

Compound 4, half-maximal inhibitory concentration: 83 nM
The estimate for compound 4 lay 2.1-fold (0.32 log units) below the measured number; the range from low to high includes it.
By their numbers in this assay, from the lowest: compounds 2, 1 and 4 (each within the scatter of the next); then compound 3.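

In this assay, going from phenyl to 4-aminophenyl gives a 1.1-fold higher number from compound 1 to compound 4 (0.04 log units; within the scatter), so on these numbers compound 4 stands level with compound 1. Among the compounds shown here, this is the first measured step at this phenyl, since every earlier step exchanged a different group, and it shows that an amino group can sit on an aromatic carbon of this ring, para to a large group, with no change beyond the scatter. For the compounds shown here, the large steps seen so far therefore remain confined to the exchange that leads to compound 3, while the one change tested on this phenyl leaves the number in place, and no measurement here bears on why it does.

As far as these compounds go, one group on one carbon cannot show how this position responds in general, so it remains open whether a carboxylic acid, a methoxy group or a longer chain ending in an amine would also leave the number in place. From the compounds shown here alone, it is also open whether the amino group would give the same result on compound 2, which carries 3-nitrophenyl instead of 2-chlorophenyl.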